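The source may report more compounds than this note shows. Statements on the series, on what has been measured and on what is new or still open speak of the compounds shown alone.

In an ADME assay on microsomes from liver (Homo sapiens) for metabolic stability (on this read-out higher numbers stand for a longer-lived compound and lower numbers for a shorter-lived compound), compound 1 `Cc1cc(C(/C=C2\OC(=O)NC2=O)C(C)C)c(=O)[nH]c1-c1ccc2cccc(F)c2c1` gives > 3 h, which is a limit of the assay and not a number. Compound 3 `CCC(CC)C(/C=C1\OC(=O)NC1=O)c1ccc(-c2ccc3cccc(F)c3c2)[nH]c1=O` gives > 3 h, also a limit. Compound 2 `CCC(/C=C1\OC(=O)NC1=O)(CC)c1ccc(-c2ccc3cccc(C(C)C)c3c2)[nH]c1=O` gives an actual number, 0.758 h. Compound 1 therefore stands at the limit of > 3 h in this assay, at which 2 of the 3 values shown sit. Compound 4 `CC(C)C(/C=C1\OC(=O)NC1=O)c1cc(Cl)c(-c2ccc3cccc(F)c3c2)[nH]c1=O` differs from compound 1 in one place: chloro in place of methyl on an aromatic carbon, with chloro in place of methyl on an aromatic carbon. Among the measured compounds shown here, no pair of measured compounds isolates this swap, so the data give no direct guide to its size. The expected change, a step that the limit leaves unreadable from compound 1 to compound 4, stays within the usual scatter and has no clear direction. For compound 4 the estimated half-life is 3.5 h, with an expected range of 1.5 h to 8 h.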

Compound 4, half-life: > 3 h
Compound 4: only a limit was reported; the forecaster's own chance of this, stated with the estimate: 65%; the middle value is on the limit's open side.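

Among the compounds shown here, compound 1 and compound 4 each give only a limit in this assay, not a number, so no step between them can be read. The compounds shown leave open whether methyl or chloro gives the longer half-life.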